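This account rests on a few compounds, and the source may have more. Where it says the series, first, only, none or still open, it means among the compounds named here.

Three compounds share one core and differ only in the aromatic group bound to an amine nitrogen. Compound 1 `Cc1cc(C(F)(F)F)cc(NC[C@@H]2CC3(CC3)CN2C(=O)c2nc(C)sc2-c2ccccc2)n1` carries a 6-methyl-4-(trifluoromethyl)pyridin-2-yl group there, and in a functional assay on HEK293 cells for antagonist activity at Orexin receptor type 2 (Homo sapiens), read by FLIPR and calcium flux (on this read-out lower numbers stand for lower potency and higher numbers for higher potency (the scale is a negative logarithm)), compound 1 gives 8.6. Compound 2 `Cc1nc(C(=O)N2CC3(CC3)C[C@H]2CNc2cc(C(F)(F)F)ccn2)c(-c2ccccc2)s1` has a hydrogen in place of one methyl on that ring; in this assay compound 2 gives 8.5, the step being a number 0.10 log units lower from compound 1 to compound 2 (within the scatter). Compound 3 `Cc1cc(C)nc(NC[C@@H]2CC3(CC3)CN2C(=O)c2nc(C)sc2-c2ccccc2)n1` carries a 4,6-dimethylpyrimidin-2-yl group instead, and in this assay compound 3 gives 8.6. Compound 3 stands level with compound 1, the two together the highest of the three numbers, and its steps from the others, no change at the digits printed from compound 1 to compound 3 (within the scatter) and a number 0.10 log units higher from compound 2 to compound 3 (within the scatter), both lie within the scatter.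

Compound 4 `Cc1nc(C(=O)N2CC3(CC3)C[C@H]2CNc2ccc(Cl)cn2)c(-c2ccccc2)s1` has not yet been measured. The change from compound 3 is 5-chloropyridin-2-yl in place of 4,6-dimethylpyrimidin-2-yl on an amine nitrogen. For the measured compounds named here, the steps that bear on it are the earlier exchanges of the aromatic group on this amine nitrogen, no change at the digits printed from compound 1 to compound 3 (within the scatter) and a number 0.10 log units higher from compound 2 to compound 3 (within the scatter), and the methyl removal a number 0.10 log units lower from compound 1 to compound 2 (within the scatter); none moved beyond the scatter. Going by the values given here, a chloropyridine variant has no precedent here, so the step is expected to be small, a number 0.20 log units lower from compound 3 to compound 4 (within the scatter), with some allowance downward. Compound 4 is estimated at 8.4, within a range from 7.9 to 8.9.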

Compound 4, negative logarithm of the antagonist equilibrium constant: 7.1
Estimate against measurement, compound 4: 1.30 log units above; the measured number lies below the stated range.
By their numbers in this assay, from the lowest: compound 4; then compounds 2, 1 and 3 (each within the scatter of the next).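

In this assay the aromatic group on this amine nitrogen proves not to be freely exchangeable: putting in 5-chloropyridin-2-yl gives a number 1.50 log units lower from compound 3 to compound 4 (beyond the scatter), and the same group gives a number 1.40 log units lower from compound 2 to compound 4 (beyond the scatter) and a number 1.50 log units lower from compound 1 to compound 4 (beyond the scatter), whereas the exchanges among the three earlier groups all stayed within the scatter. For the compounds shown here, the earlier compounds therefore showed only that a pyrimidine and two substituted pyridines are tolerated alike, and compound 4 is the first to show that this position can lose much of the potency while the rest of the molecule stays the same, making it the least potent of the four. Nothing available here explains the size of this fall.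

Compound 2 and compound 4 are both pyridin-2-yl compounds, but they differ in the group on the ring and in where it sits, so the compounds shown cannot tell whether the chlorine or its place on the ring goes with the lower number. A plain pyridin-2-yl group and a 5-(trifluoromethyl)pyridin-2-yl group on the same amine nitrogen would help to pull these two apart.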